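The source may hold more compounds than are shown below. What is called first, only, known or untested is meant among the compounds shown, and "the series" means these compounds.

Measured in an ADME assay for lipophilicity; on this read-out higher numbers stand for higher lipophilicity and lower numbers for lower lipophilicity:
- compound 1 `COCc1cc(=O)c(O)co1`: -0.62
- compound 2 `CCOCc1cc(=O)c(O)co1`: -0.38
- compound 3 `CCCCn1ccc(=O)c(O)c1C`: 0.71

Compound 3 has the highest number of the three, and its gaps to compound 2 and to compound 1 both lie beyond the scatter. The next compound to be measured is compound 4 `CCCCCCn1ccc(=O)c(O)c1C`. Its difference from compound 3 is ethyl in place of hydrogen on a saturated chain carbon, four bonds along the chain from an aromatic nitrogen.

Among the compounds with values here, only one measured step adds to a saturated chain: a number 0.24 log units higher from compound 1 to compound 2 (within the scatter), with methyl in place of hydrogen. It sits at a different place on a different core, so it is only a loose guide. Ethyl is the larger group, so a rise greater than that step is expected in this assay. The expected step is a number 0.79 log units higher from compound 3 to compound 4 (beyond the scatter). Compound 4 is estimated at 1.5, with an expected range of 1.1 to 2.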

Compound 4, distribution coefficient: 1.9
Compound 4: the middle estimate sits 0.40 log units below what was measured, within the range that was stated.
By their numbers in this assay, from the lowest: compounds 1 and 2 (each within the scatter of the next); then compound 3; then compound 4.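

In this assay, ethyl in place of hydrogen on a saturated chain carbon, four bonds along the chain from an aromatic nitrogen, gives a number 1.19 log units higher from compound 3 to compound 4 (beyond the scatter). This place on the chain therefore takes a two-carbon addition with a step that is large and clearly beyond the scatter. Within the data shown here, the only earlier chain step, a number 0.24 log units higher from compound 1 to compound 2 (within the scatter), stayed within the scatter, but it is a methyl change at a different place on a different core, so the two steps give no common rule, and nothing available bears on the size of the new step.

On these data alone, this position rests on a single step on the core of compound 3, so whether a longer chain would extend the rise remains open. As far as these compounds go, what an amine or a carboxylic acid would give in place of the ethyl is equally open.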